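Moving one chlorine on the benzyl group

The source may report more compounds than this note shows. Statements on the series, on what has been measured and on what is new or still open speak of the compounds shown alone.

Among the compounds with values here, in a functional assay on MDA-MB-231 cells (Homo sapiens) for cytotoxicity, read by MTT assay, with a stated time of 24 h (a higher number here means a weaker inhibitor, a lower number a stronger inhibitor), compound 1 (`Cc1ccc(/C=C2\CN(C(=S)SCc3cn(Cc4cccc(Cl)c4)nn3)C/C(=C\c3ccc(C)cc3)C2=O)cc1`) gives 83000 nM as the only true number so far. Compound 2 (`O=C1/C(=C/c2ccccc2F)CN(C(=S)SCc2cn(Cc3cccc(Cl)c3)nn2)C/C1=C\c1ccccc1F`) reads > 100000 nM as a limit of the assay, not a number. Compound 3 (`COc1ccc(/C=C2\CN(C(=S)SCc3cn(Cc4ccccc4Cl)nn3)C/C(=C\c3ccc(OC)cc3)C2=O)cc1`) reads > 100000 nM as a limit too. Compound 4 (`Cc1ccc(/C=C2\CN(C(=S)SCc3cn(Cc4ccccc4Cl)nn3)C/C(=C\c3ccc(C)cc3)C2=O)cc1`) awaits measurement. It differs from compound 1 by a single swap, (2-chlorophenyl in place of 3-chlorophenyl on a saturated chain carbon bound to an aromatic nitrogen), namely 2-chlorophenyl in place of 3-chlorophenyl on a saturated chain carbon bound to an aromatic nitrogen. Within the data shown here, no measured pair shows this swap, so no change beyond the usual scatter is expected in this assay, and the expected size is a 1.1-fold higher number from compound 1 to compound 4 (0.04 log units; within the scatter) overall. For compound 4 the estimated value is 90000 nM, with an expected range from 50000 nM to 160000 nM for the measurement.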

Compound 4, half-maximal inhibitory concentration: 93200 nM
Estimate against measurement, compound 4: 1.0-fold (0.02 log units) below; low and high end bracket the measured number.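

Putting 2-chlorophenyl in place of 3-chlorophenyl on a saturated chain carbon bound to an aromatic nitrogen gives a 1.1-fold higher number from compound 1 to compound 4 (0.05 log units; within the scatter) in this assay. Within the data shown here, this is the first pair that differs in one place, and the two chlorine positions cannot be told apart here. Both numbers also lie close to the top of what the test can read, which leaves little room to see a difference: the limit of > 100000 nM in this assay, at which 2 of the 4 values shown sit.

Still open, on these data alone, is whether an amine or a carboxylic acid in place of the chlorine would give a stronger inhibitor. As far as these compounds go, whether the same swap behaves alike on a core with other groups also remains unknown.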